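The source may report more compounds than this note shows. Statements on the series, on what has been measured and on what is new or still open speak of the compounds shown alone.

Measured so far in a functional assay on HCT-15 cells (Homo sapiens) for inhibition, read by sulforhodamine B assay, with a stated time of 48 h, tested at 10 uM; on this read-out lower numbers stand for less inhibition and higher numbers for more inhibition at the one concentration tested (going by the name of the read-out):
compound 1, `c1ccc(-c2cn3ccnc3c(-c3ccc4ncn(C5CCCCC5)c4c3)n2)cc1`, gives 51.6%
compound 2, `c1ccc2c(-c3cn4ccnc4c(-c4ccc5ncn(C6CCCCC6)c5c4)n3)cccc2c1`, gives 4.46%
compound 3, `Brc1ccc(-c2cn3ccnc3c(-c3ccc4ncn(C5CCCCC5)c4c3)n2)cc1`, gives 35.8%

Compound 2 stands lowest of the three in this assay, with both other compounds beyond the scatter above it. The unmeasured compound 4, `c1csc(-c2cn3ccnc3c(-c3ccc4ncn(C5CCCCC5)c4c3)n2)c1`, differs from compound 2 in one place: thiophen-2-yl in place of naphthalen-1-yl on an aromatic carbon. Among the compounds with values here, two measured steps bear on this. Adding the naphthalen-1-yl gave a number 47.1 percentage points lower from compound 1 to compound 2 (beyond the scatter), and swapping it for a smaller ring gave a number 31.3 percentage points higher from compound 2 to compound 3 (beyond the scatter). Thiophen-2-yl is again a small single ring, so a large rise is expected. Compound 4 is therefore estimated to reach 45%, within a range of 20% to 65%, corresponding to an expected step of a number 40.5 percentage points higher from compound 2 to compound 4 (beyond the scatter).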

Compound 4, a percentage reported as inhibition, at one concentration (the size of the read-out at that concentration, not a potency): 2.33%
Estimate against measurement, compound 4: 42.7 percentage points above; measured number below the stated range.
By their numbers in this assay, from the lowest: compounds 4 and 2 (each within the scatter of the next); then compound 3; then compound 1.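

In this assay, a small single ring at this position does not by itself bring a high number: thiophen-2-yl stands level with the much larger naphthalen-1-yl (a number 2.1 percentage points lower from compound 2 to compound 4 (within the scatter)). The kind of single ring matters, as thiophen-2-yl falls short of both 4-bromophenyl (a number 33.5 percentage points lower from compound 3 to compound 4 (beyond the scatter)) and phenyl (a number 49.3 percentage points lower from compound 1 to compound 4 (beyond the scatter)). No measurement shown gives a reason for this. Still open, on these data alone, is what an amine or a carboxylic acid on the phenyl ring would do here. Pyridin-3-yl, a six-membered ring containing nitrogen, also remains an open case.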